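The source may report more compounds than this note shows. Statements on the series, on what has been measured and on what is new or still open speak of the compounds shown alone.

In a functional assay on LNCaP cells (Homo sapiens) for antiproliferative activity, read by propidium iodide staining, with a stated time of 96 h (on this read-out higher numbers stand for weaker inhibition and lower numbers for stronger inhibition), compound 1 (`CC(O)(CSc1cccc(C(F)(F)F)c1)C(=O)Nc1cccc(S(F)(F)(F)(F)F)c1`) gives 12700 nM and compound 2 (`CC(O)(CS(=O)(=O)c1ccccc1C(F)(F)F)C(=O)Nc1ccc(S(F)(F)(F)(F)F)cc1`) gives 10800 nM as its reading. Compound 3 (`CC1(C)C(=O)N(c2cccc(S(F)(F)(F)(F)F)c2)C(=S)N1c1ccc(C(F)(F)F)cc1`) gives 5200 nM as its reading, the lowest number of the three and beyond the scatter from both others. Compound 4 (`CC1(C)C(=O)N(c2cccc(S(F)(F)(F)(F)F)c2)C(=S)N1c1cccc(C(F)(F)F)c1`) differs from it in one place (3-(trifluoromethyl)phenyl in place of 4-(trifluoromethyl)phenyl on an amide-type nitrogen in a ring), with 3-(trifluoromethyl)phenyl in place of 4-(trifluoromethyl)phenyl on an amide-type nitrogen in a ring. Going by the values given here, no measured pair shows what such a swap does, so only a small rise in the number is expected in this assay, near the edge of the scatter. The estimated change is a 1.3-fold higher number from compound 3 to compound 4 (0.13 log units; within the scatter) on this read-out. Compound 4 is estimated at 7000 nM within a range of 2800 nM to 16000 nM on this read-out.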

Compound 4, half-maximal inhibitory concentration: 3400 nM
Compound 4: middle estimate off by 2.1-fold (0.31 log units), on the high side, and the stated range covers the measured number.
By their numbers in this assay, from the lowest: compounds 4 and 3 (each within the scatter of the next); then compounds 2 and 1 (each within the scatter of the next).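

In this assay, 3-(trifluoromethyl)phenyl in place of 4-(trifluoromethyl)phenyl on the amide-type nitrogen in the ring gives the only single-place step among the compounds shown (a 1.5-fold lower number from compound 3 to compound 4 (0.18 log units; within the scatter)). At this nitrogen, the reading does not separate the two groups, which have the same atoms joined differently. No measured evidence accompanies this result to explain it. The compounds shown leave open what a nitrile or a carboxylic acid in place of the trifluoromethyl on this phenyl would give, and whether the same swap reads alike on another core.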